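A few compounds are considered here, and "the series" means these few. Any claim that something is new, unique, unknown or untested is made for them only; others in the source may bear on it.

Values in a functional assay on HL-60 cells (Homo sapiens) for inhibition, read by MTT assay, with a stated time of 72 h; a higher number here means a weaker inhibitor, a lower number a stronger inhibitor:
- compound 1 `COc1cccc(N2CCN(C(=O)c3oc(C)nc3-c3ccccc3F)CC2)c1`: 56.1 nM
- compound 2 `COc1cccc(N2CCN(C(=O)c3oc(C)nc3-c3ccc(F)cc3)CC2)c1`: 112 nM
- compound 3 `Cc1nc(-c2cccc(F)c2)c(C(=O)N2CCN(c3cc(Cl)cc(Cl)c3)CC2)o1`: 41.7 nM

Compound 3 sits within the scatter of compound 1 and beyond the scatter on the lower side of compound 2. Compound 4 `COc1cccc(N2CCN(C(=O)c3oc(C)nc3-c3cccc(F)c3)CC2)c1` has 3-methoxyphenyl in place of 3,5-dichlorophenyl on an amine nitrogen in a ring, with this count: 3-methoxyphenyl in place of 3,5-dichlorophenyl on an amine nitrogen in a ring. Within the data shown here, no measured step covers this change directly. Among the measured compounds shown here, compound 1 and compound 2 already carry 3-methoxyphenyl, and the only measured step, a 2.0-fold higher number from compound 1 to compound 2 (0.30 log units; within the scatter), concerns the fluorophenyl group alone. In this assay no step beyond the scatter is therefore expected, though the number may rise slightly. The expected step is a 1.7-fold higher number from compound 3 to compound 4 (0.22 log units; within the scatter). The estimated value for compound 4 is 70 nM, with an expected range of 30 nM to 165 nM.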

Compound 4, half-maximal inhibitory concentration: "not active" (no number reported)
The entry for compound 4 holds no number, and the estimate cannot be compared.
By their numbers in this assay, from the lowest: compounds 3, 1 and 2 (each within the scatter of the next, the first and the last beyond it).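

Among these compounds, compound 4 is reported as "not active" in this assay without a number, so no step from compound 3 can be read. The compounds shown leave open what 3-methoxyphenyl in place of 3,5-dichlorophenyl does to the number on this core. No available evidence bears on this result.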